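A few compounds are considered here, and "the series" means these few. Any claim that something is new, unique, unknown or untested is made for them only; others in the source may bear on it.

In a functional assay on HepG2 cells (Homo sapiens) for antiproliferative activity, read by sulforhodamine B assay, with a stated time of 48 h (on this read-out lower numbers stand for stronger inhibition and higher numbers for weaker inhibition), three compounds lie close together: compound 1 `COc1cccc(/C=C/C(=O)C(=Cc2cc(OC)c(OC)c(OC)c2)C(=O)/C=C/c2cccc(OC)c2OC)c1OC` gives 220 nM, compound 2 `COc1cccc(C=C(C(=O)/C=C/c2cccc(OC)c2OC)C(=O)/C=C/c2cccc(OC)c2OC)c1OC` gives 230 nM and compound 3 `COc1cc(C=C(C(=O)/C=C/c2cccc(OC)c2OC)C(=O)/C=C/c2cccc(OC)c2OC)cc(Br)c1O` gives 240 nM, so compound 3 stands level with both others within the scatter. Compound 4 `COc1cc(C=C(C(=O)/C=C/c2cccc(OC)c2OC)C(=O)/C=C/c2cccc(OC)c2OC)cc(OC)c1O` differs from compound 3 by methoxy in place of bromo on an aromatic carbon. Within the data shown here, no measured step makes this exact exchange. The nearest evidence comes from exchanges of the whole aryl group: a 1.1-fold higher number from compound 1 to compound 3 (0.04 log units; within the scatter), a 1.0-fold higher number from compound 2 to compound 3 (0.02 log units; within the scatter) and a 1.0-fold higher number from compound 1 to compound 2 (0.02 log units; within the scatter), all within the scatter. No step beyond the scatter is therefore expected in this assay. The estimate amounts to an expected 1.0-fold lower number from compound 3 to compound 4 (0.02 log units; within the scatter). Compound 4 is expected at 230 nM, with an estimated range from 110 nM to 480 nM.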

Compound 4, half-maximal inhibitory concentration: 210 nM
The estimate for compound 4 lay 1.1-fold (0.04 log units) above the measured number, within the range that was stated.
By their numbers in this assay, from the lowest: compounds 4, 1, 2 and 3 (each within the scatter of the next).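

In this assay, the direct exchange of bromo for methoxy on this aromatic carbon, ortho to a hydroxy group, gives (a 1.1-fold lower number from compound 3 to compound 4 (0.06 log units; within the scatter)), so the earlier whole-aryl comparisons now have a direct reading at this position. The 4-hydroxy-3,5-dimethoxyphenyl group also stands level with 2,3-dimethoxyphenyl (a 1.1-fold lower number from compound 2 to compound 4 (0.04 log units; within the scatter)), and hydrogen in place of methyl on an oxygen on the aromatic ring leaves the number level too (a 1.0-fold lower number from compound 1 to compound 4 (0.02 log units; within the scatter)). Nothing available accounts for this flatness.

Going by these compounds, whether an amine or a carboxylic acid on this aromatic carbon would stay level remains open. So does whether any exchange on this aryl group can move the number beyond the scatter.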